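This account rests on a few compounds, and the source may have more. Where it says the series, first, only, none or still open, it means among the compounds named here.

The study, in an assay for inhibition of Hematopoietic prostaglandin D synthase (Homo sapiens), read by fluorescence, with a stated time of 30 min (on this read-out higher numbers stand for weaker inhibition and lower numbers for stronger inhibition), brings together three measured compounds. Compound 1 `CC(C)(O)c1nc(-c2ccc(CNC(=O)c3cnc(-c4ccccn4)nc3)cc2)no1` gives 70 nM, compound 3 `COCCCNC(=O)c1nc(-c2cccc3[nH]ccc23)no1` gives 170 nM, and compound 2 `CN(C)CCC(=O)Nc1cncc(-c2cccc3[nH]ccc23)c1` gives 300 nM. Compound 2 thus stands beyond the usual scatter from compound 1 and within it from compound 3, so against compound 3 no ordering can be read from the numbers.

Compound 4 `O=C(CCN1CCCCC1)Nc1cncc(-c2cccc3[nH]ccc23)c1`, not yet measured in this assay, differs from compound 2 in one place: piperidin-1-yl in place of dimethylamino on a saturated chain carbon, two bonds along the chain from a carbonyl carbon. Among the measured compounds shown here, no comparable step between two measured compounds exists here, and nothing in the three numbers points to a direction for this change. A tertiary amine at the end of the chain remains in both structures, with only its ring-closed form entering. The step expected from this change, a 1.1-fold lower number from compound 2 to compound 4 (0.03 log units; within the scatter), is therefore estimated to stay within the scatter, in no particular direction. For compound 4 the estimate in this assay is 280 nM, with a range from 110 nM to 700 nM.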

Compound 4, half-maximal inhibitory concentration: 130 nM
For compound 4 the middle estimate is 2.2-fold (0.33 log units) above the measured one, within the range that was stated.
By their numbers in this assay, from the lowest: compounds 1, 4, 3 and 2 (each within the scatter of the next, the first and the last beyond it).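

In this assay the end of this chain, on a saturated chain carbon two bonds along the chain from a carbonyl carbon, proves responsive to the amine placed there: piperidin-1-yl in place of dimethylamino gives a 2.3-fold lower number from compound 2 to compound 4 (0.36 log units; beyond the scatter) as a modest step towards stronger inhibition. Among the compounds shown here, the earlier compounds offered no step at this place, so this is the first sign that the ring-closed amine is accepted here and that the change can move the number beyond the usual scatter. Nothing measured here bears on why the number moves.

As far as these compounds go, whether the step belongs to the closed ring or simply to the added carbons stays open, and a diethylamino, pyrrolidin-1-yl or morpholin-4-yl group at the same place would help to separate the two. From the compounds shown here alone, it is also open whether the step would hold on a longer chain between the carbonyl and the amine.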